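A Longer Ester Arm and Its Expected Cytotoxicity

The compounds below may be only part of what the source reports. "The series", "measured", "known", "first", "only" and "open" are said of these compounds alone.

Compound 1 `Cc1cn([C@@H]2O[C@H](CO[Si](C)(C)C(C)(C)C)[C@@]3(OS(=O)(=O)C=C3NC(N)=O)[C@H]2O[Si](C)(C)C(C)(C)C)c(=O)n(C)c1=O` — 16000 nM
Compound 2 `Cc1cn([C@@H]2O[C@H](CO[Si](C)(C)C(C)(C)C)[C@@]3(OS(=O)(=O)C=C3NCC(=O)OCc3ccccc3)[C@H]2O[Si](C)(C)C(C)(C)C)c(=O)n(C)c1=O` — >= 400000 nM, a limit of the assay

Among the measured compounds shown here, in a functional assay on HEL cells (Homo sapiens) for cytotoxicity, read by microscopy (on this read-out lower numbers stand for higher toxicity in this test and higher numbers for lower toxicity in this test), compound 1 gives 16000 nM, the only plain number among the two values shown. The other value is the limit of >= 400000 nM in this assay, at which 1 of the 2 values shown sits, and it belongs to compound 2. Compound 3 `Cc1cn([C@@H]2O[C@H](CO[Si](C)(C)C(C)(C)C)[C@@]3(OS(=O)(=O)C=C3NCCC(=O)OCc3ccccc3)[C@H]2O[Si](C)(C)C(C)(C)C)c(=O)n(C)c1=O` differs from compound 1 by 2-(benzyloxycarbonyl)ethyl in place of carbamoyl on an amine nitrogen. For the measured compounds named here, the one measured step that bears on this change, an at least 25-fold higher number from compound 1 to compound 2 (1.39 log units; beyond the scatter), was large and ran toward a limit. Compound 3 is therefore expected to move the same way, with an estimated 300000 nM (range 80000 nM to 400000 nM), meaning an expected 19-fold higher number from compound 1 to compound 3 (1.27 log units; beyond the scatter).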

Compound 3, minimum cytotoxic concentration: >= 400000 nM
Compound 3: a limit, no number; the forecaster's own chance of this, stated with the estimate: 65%; at least 1.3-fold (0.12 log units) between middle value and limit.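

Replacing carbamoyl on the amine nitrogen with 2-(benzyloxycarbonyl)ethyl gives an at least 25-fold higher number from compound 1 to compound 3 (1.39 log units; beyond the scatter) in this assay. The large rise seen with (benzyloxycarbonyl)methyl in compound 2 therefore also appears with the 2-(benzyloxycarbonyl)ethyl group of compound 3. The step from compound 2 to compound 3 cannot be read, because both compounds sit at the same limit: the limit of >= 400000 nM in this assay, at which 2 of the 3 values shown sit.

Any difference between these two arms therefore stays open. So does the effect of a carboxylic acid in place of the benzyl ester at the end of the chain.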